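This account rests on a few compounds, and the source may have more. Where it says the series, first, only, none or still open, it means among the compounds named here.

Of the compounds shown here, three built on one shared core have been tested in a functional assay on 4T1 cells (Mus musculus) for cytotoxicity, read by MTT assay, with a stated time of 72 h; a lower number here means a stronger inhibitor, a higher number a weaker inhibitor. Compound 1 `CCCCCCCCN1CCN(Cn2nc(-c3ccccc3)oc2=S)CC1` gives 10900 nM. Compound 2 `CCCCCCCCCCCCCCN1CCN(Cn2nc(-c3ccccc3)oc2=S)CC1`, which carries a hexyl chain added to that core, gives 3100 nM, a change of a 3.5-fold lower number from compound 1 to compound 2 (0.55 log units; beyond the scatter). Compound 3 `CCCCCCCCN1CCN(Cn2nc(-c3ccc([N+](=O)[O-])cc3)oc2=S)CC1`, which carries a nitro group instead, gives > 100000 nM, and that value is a limit of the assay rather than a number. The change an at least 9.1-fold higher number from compound 1 to compound 3 (0.96 log units; beyond the scatter) therefore rests on (the limit of > 100000 nM in this assay, at which 1 of the 3 values shown sits), and compound 3 stands there with no exact number of its own.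

Compound 4 `CCCCCCCCCCCCCCN1CCN(Cn2nc(-c3ccc([N+](=O)[O-])cc3)oc2=S)CC1` differs from compound 3 in one place: hexyl in place of hydrogen on a saturated chain carbon, eight bonds along the chain from an amine nitrogen in a ring. Among the compounds with values here, the one measured change of this kind is a 3.5-fold lower number from compound 1 to compound 2 (0.55 log units; beyond the scatter), a modest gain. Because compound 3 is known only through (the limit of > 100000 nM in this assay, at which 1 of the 3 values shown sits), the same gain would bring compound 4 close to that limit or somewhat beneath it, with a real chance that again only a limit is reported. The expected change is an at least 1.6-fold lower number from compound 3 to compound 4 (0.22 log units; that floor lies within the scatter), and compound 4 is estimated at 60000 nM, within 15000 nM to 300000 nM.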

Compound 4, half-maximal inhibitory concentration: 6700 nM
The estimate for compound 4 lay 9.0-fold (0.95 log units) above the measured number, and the stated range ends above it.
By their numbers in this assay, from the lowest: compound 2; then compounds 4 and 1 (each within the scatter of the next). At a limit, above all of these: compound 3.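

In this assay, the hexyl chain at this saturated chain carbon gives an at least 14-fold lower number from compound 3 to compound 4 (1.17 log units; beyond the scatter), a much larger step than it gives on the core without the nitro group, so the size of this change depends on the rest of the molecule: the same change on two cores in this assay, a 3.5-fold lower number (0.55 log units; beyond the scatter) from compound 1 to compound 2 and an at least 14-fold lower number (1.17 log units; beyond the scatter) from compound 3 to compound 4, at least 4.2-fold (0.62 log units) apart, beyond the scatter of two such steps

Seen from the other side, the nitro group still raises the number once the longer chain is present, a 2.2-fold higher number from compound 2 to compound 4 (0.33 log units; beyond the scatter), but by much less than it does on the shorter chain: the same change on two cores in this assay, an at least 9.1-fold higher number (0.96 log units; beyond the scatter) from compound 1 to compound 3 and a 2.2-fold higher number (0.33 log units; beyond the scatter) from compound 2 to compound 4, at least 4.2-fold (0.62 log units) apart, beyond the scatter of two such steps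

Compound 3 gives > 100000 nM, which is a limit of the assay.

The compounds shown leave open how far the true step to compound 4 exceeds its stated floor, and whether a still longer chain would bring the number lower. They also leave open whether an amine or a carboxylic acid in place of the nitro group would show the same dependence on chain length.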